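Sulfonyl to Sulfanyl Swap on Two Aryl Cores

The compounds below may be only part of what the source reports. "The series", "measured", "known", "first", "only" and "open" are said of these compounds alone.

Compound 1, `CS(=O)(=O)c1cc(F)ccc1NCC1=NCCN1`: 513 nM
Compound 2, `CSc1cc(F)ccc1NCC1=NCCN1`: 15.1 nM
Compound 3, `CS(=O)(=O)c1ccc(Cl)cc1NCC1=NCCN1`: 2950 nM

The three compounds were measured in an assay for binding affinity to Alpha-1B adrenergic receptor (Homo sapiens), read by radioligand binding; on this read-out lower numbers stand for stronger inhibition and higher numbers for weaker inhibition. Compound 1 and compound 2 share a core and differ by methylsulfanyl in place of methylsulfonyl on an aromatic carbon; this change gave a 34-fold lower number from compound 1 to compound 2 (1.53 log units; beyond the scatter). Compound 3 has the highest number of the three. Compound 4, `CSc1ccc(Cl)cc1NCC1=NCCN1`, is not yet measured and arises from compound 3 by methylsulfanyl in place of methylsulfonyl on an aromatic carbon. The two changes are the same kind of change, not the same: in compound 1 the place is meta to a fluoro group, in compound 3 it is para to a chloro group. The difference between the two cores is not broken down here. The expectation rests on a 34-fold lower number from compound 1 to compound 2 (1.53 log units; beyond the scatter). For compound 4 the expected step is a 30-fold lower number from compound 3 to compound 4 (1.47 log units; beyond the scatter). Compound 4 is estimated at 100 nM, expected between 30 nM and 350 nM.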

Compound 4, inhibition constant: 69.2 nM
The estimate for compound 4 lay 1.4-fold (0.16 log units) above the measured number; low and high end bracket the measured number.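

Methylsulfanyl in place of methylsulfonyl gave a 43-fold lower number from compound 3 to compound 4 (1.63 log units; beyond the scatter) in this assay, and the step held its size when carried from one core to the other: the same change on two cores in this assay, a 34-fold lower number (1.53 log units; beyond the scatter) from compound 1 to compound 2 and a 43-fold lower number (1.63 log units; beyond the scatter) from compound 3 to compound 4, 1.3-fold (0.10 log units) apart, within the scatter of two such steps. On these two cores, then, the change can be carried over with its size kept, although its place relative to the halogen differs between them. Two pairs do not make a rule for other cores in the series, however, and they do not show why the step is so large.

The compounds shown leave open what other groups would do in the same place, such as a methoxy group, an amine or a longer chain like ethylsulfanyl. They also leave open whether the step would survive with a bromo group or with no halogen on the ring.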